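Three Measured Analogues and a Methoxyphenyl Variant Awaiting Assay

A few compounds are considered here, and "the series" means these few. Any claim that something is new, unique, unknown or untested is made for them only; others in the source may bear on it.

Three compounds share a common core that carries an acetic acid chain and a benzylidene arm, and all three were tested in an assay on HL-60 cells for inhibition of glutathione S-transferase P (Homo sapiens), read by spectrophotometry, tested at 20 uM; on this read-out higher numbers stand for more inhibition at the one concentration tested (going by the name of the read-out) and lower numbers for less inhibition. Compound 1 `COc1ccccc1/C=C1\CN(CC(=O)O)c2c(C)cccc2C1=O` gives 4.72%. Compound 2 `COc1ccc(/C=C2\CN(CC(=O)O)c3c(Cl)cccc3C2=O)c(OC)c1OC` gives 23.6%. Compound 3 `Cc1ccc2c(c1)C(=O)/C(=C/c1ccc(Br)cc1)CN2CC(=O)O` gives 28.2%, the highest of the three numbers; its gap to compound 2 lies within the scatter, while its gap to compound 1 lies beyond it, so compound 3 cannot be said to give a higher number than compound 2, only clearly a higher number than compound 1.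

Compound 4 `COc1cccc(/C=C2\CN(CC(=O)O)c3ccc(C)cc3C2=O)c1` has not yet been measured in this assay. It differs from compound 3 in one place: 3-methoxyphenyl in place of 4-bromophenyl on a double-bonded chain carbon bound to a double-bonded ring carbon.

Going by the values given here, no pair of measured compounds differing in a single place is available, so the size of this step cannot be read from the numbers at hand. Compound 1, which also carries a methoxy-bearing aryl group, gives the lowest value, so a step downward from compound 3 is expected, of a size a number 10.2 percentage points lower from compound 3 to compound 4 (beyond the scatter) that may well remain within the scatter. Compound 4 is expected to give roughly 18%, between 3% and 35%.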

Compound 4, a percentage reported as inhibition, at one concentration (the size of the read-out at that concentration, not a potency): 14.4%
For compound 4 the middle estimate is 3.6 percentage points above the measured one; the range from low to high includes it.
By their numbers in this assay, from the lowest: compounds 1, 4, 2 and 3 (each within the scatter of the next, the first and the last beyond it).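

In this assay the series now holds its first pair differing in a single place: 3-methoxyphenyl in place of 4-bromophenyl on a double-bonded chain carbon bound to a double-bonded ring carbon gives a number 13.8 percentage points lower from compound 3 to compound 4 (beyond the scatter) and so shows that the read-out responds to a change at this position. The step is modest, and this one pair cannot separate the departure of the bromine from the arrival of the methoxy group. Nothing at hand accounts for the size or direction of the step.

From the compounds shown here alone, whether a phenyl ring without any further group, or a phenyl ring bearing an amine or a nitrile, would give a higher or lower number at this position stays open. Also open, going by these compounds, is whether the same exchange would give a step of similar size on the cores of compound 1 and compound 2.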